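Swapping the aryl group on a nitroimidazole thioether

The compounds below may be only part of what the source reports. "The series", "measured", "known", "first", "only" and "open" are said of these compounds alone.

The two measured compounds share one core. Among the compounds with values here, compound 1 `Cc1ccccc1-c1nnc(SCCn2c([N+](=O)[O-])cnc2C)o1` gives 5100 nM in a functional assay on HepG2 cells (Homo sapiens) for cytotoxicity, read by MTT assay, with a stated time of 48 h (a higher number here means a weaker inhibitor, a lower number a stronger inhibitor), and compound 2 `Cc1ncc([N+](=O)[O-])n1CCSc1nnc(-c2ccccc2O)o1` gives 19600 nM, the higher of the two numbers; the only measured step, a 3.8-fold higher number from compound 1 to compound 2 (0.58 log units; beyond the scatter), separates them. Compound 3 `Cc1ncc([N+](=O)[O-])n1CCSc1nnc(-c2ccnc(Cl)c2)o1` has not yet been measured. It differs from compound 2 by 2-chloropyridin-4-yl in place of 2-hydroxyphenyl on an aromatic carbon. Within the data shown here, no measured step covers this change directly. Among the measured compounds shown here, the one step that touches the same ring, hydroxy in place of methyl, raised the number moderately, so removing the hydroxy group again is expected to bring the number back toward that of compound 1, though the chloropyridinyl ring is untested. Compound 3 is therefore expected to show a modest drop, a 2.5-fold lower number from compound 2 to compound 3 (0.39 log units; beyond the scatter), with an estimated value of 8000 nM in this assay, most likely between 3000 nM and 25000 nM.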

Compound 3, half-maximal inhibitory concentration: 11600 nM
Beside the measured number, compound 3's estimate is 1.5-fold (0.16 log units) below it; the measured number falls inside the stated range.
By their numbers in this assay, from the lowest: compound 1; then compounds 3 and 2 (each within the scatter of the next).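

In this assay, 2-chloropyridin-4-yl in place of 2-hydroxyphenyl gives a 1.7-fold lower number from compound 2 to compound 3 (0.23 log units; within the scatter) and so leaves the two numbers indistinguishable, even though the hydrogen-bond donor is gone and the ring now holds a hetero atom. Set against the 2-methylphenyl group, the same new group gives a 2.3-fold higher number from compound 1 to compound 3 (0.36 log units; beyond the scatter) and compound 1, whose steps to both others lie beyond the scatter, remains the strongest of the three. No evidence at hand accounts for these differences.

As far as these compounds go, compound 3 brings in the ring nitrogen and the chlorine together, so their separate contributions stay open. Also open, from the compounds shown here alone, is how an unsubstituted phenyl ring, or an amine or a carboxylic acid on this ring, would compare with these three compounds.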